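The compounds below may be only part of what the source reports. "The series", "measured", "known", "first", "only" and "open" are said of these compounds alone.

In a functional assay on the whole organism for antagonist activity, with Mus musculus as the target (on this read-out lower numbers stand for an effect already at smaller amounts and higher numbers for an effect only at larger amounts of compound), compound 1 `CSc1nnc(-c2ccc(C)cc2)n1C` gives > 100 mg/kg, which is a limit and not a number. Compound 2 `Cc1ccc(-c2nnc([S+](C)[O-])n2C)cc1` gives > 200 mg/kg, also a limit. Compound 3 `Cc1ccc(-c2nnc(S(C)(=O)=O)n2C)cc1` gives > 200 mg/kg, again a limit. The measured steps are a step that the two limits leave unreadable from compound 1 to compound 2, a step that the two limits leave unreadable from compound 1 to compound 3 and a step that the two limits leave unreadable from compound 2 to compound 3. All of them change the sulfur-bearing group, so none has a readable size to carry over.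

Compound 4 `COc1ccc(-c2nnc([S+](C)[O-])n2C)cc1` has methoxy in place of methyl on an aromatic carbon. For the measured compounds named here, no measured step touches this place, so no direction can be read, and no change beyond the scatter is expected in this assay. The expected step is a number no higher from compound 2 to compound 4 (the limit leaves the size open). The estimate for compound 4 is 200 mg/kg, with an expected range from 80 mg/kg to 400 mg/kg.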

Compound 4, dose for half-maximal effect: > 100 mg/kg
Compound 4 ended at the assay's limit; the forecaster's own chance of this, stated with the estimate: 70%; the middle value lies beyond the limit too.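

Compound 2 and compound 4 both give limits and not numbers, so the step between them, methoxy in place of methyl, cannot be read. The compounds shown leave open what dose any of them would need for a half-maximal effect.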